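The source may hold more compounds than are shown below. What is called first, only, known or untested is meant among the compounds shown, and "the series" means these compounds.

Measured compounds:
compound 1 `Cc1cnc(Nc2ccc(C(C)C)cc2)nc1Nc1nc2ccccc2s1`: > 50000 nM
compound 2 `NS(=O)(=O)c1ccc(Nc2nccc(Nc3nc4ccc(F)cc4s3)n2)cc1`: 10900 nM

Both were tested in a functional assay on MCF7 cells (Homo sapiens) for antiproliferative activity, read by MTT assay, with a stated time of 48 h; on this read-out lower numbers stand for stronger inhibition and higher numbers for weaker inhibition. Compound 1 gives > 50000 nM, which is a limit of the assay rather than a measured number; compound 1 therefore stands at the limit of > 50000 nM in this assay, at which 1 of the 2 values shown sits. Compound 2, built on a different core, gives 10900 nM in this assay. Within the data shown here, no step between compounds that differ in a single place has been measured, so compound 1 stands on its own at the limit, and nothing ties it to compound 2 beyond what the two values themselves show.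

Compound 3 `Cc1cnc(Nc2ccc(N3CCCCC3)cc2)nc1Nc1nc2ccccc2s1` differs from compound 1 in one place: piperidin-1-yl in place of isopropyl on an aromatic carbon. Among the measured compounds shown here, with compound 1 only at a limit, no measured step can set the size of this change. The step from compound 1 to compound 3 is expected to be an at least 1.6-fold lower number from compound 1 to compound 3 (0.22 log units; that floor lies within the scatter), small or at most a modest gain that may bring compound 3 into the measurable range. The estimate for compound 3 is 30000 nM, ranging from 6000 nM to 150000 nM.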

Compound 3, half-maximal inhibitory concentration: > 50000 nM
Compound 3: a limit, no number; the forecaster's own chance of this, stated with the estimate: 55%; at least 1.6-fold (0.22 log units) between middle value and limit.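

Among these compounds, compound 1 and compound 3 both sit at a limit of the assay rather than at a measured number, so no step between them can be read: the limit of > 50000 nM in this assay, at which 2 of the 3 values shown sit.

The compounds shown leave open how far piperidin-1-yl and isopropyl differ in effect, and whether any group in that place brings the core of compound 1 into the measurable range.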